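The source may report more compounds than this note shows. Statements on the series, on what has been measured and on what is new or still open speak of the compounds shown alone.

Of the compounds shown here, two have numbers so far in a functional assay on CWR22R cells (Homo sapiens) for antiproliferative activity, read by propidium iodide staining, with a stated time of 96 h; on this read-out lower numbers stand for stronger inhibition and higher numbers for weaker inhibition. Compound 1 (`CC(O)(COc1cccc(S(F)(F)(F)(F)F)c1)C(=O)Nc1cc(C(F)(F)F)cc(C(F)(F)F)c1`) gives 2300 nM. Compound 2 (`CC(O)(CS(=O)(=O)c1cccc(S(F)(F)(F)(F)F)c1)C(=O)Nc1ccc(S(F)(F)(F)(F)F)cc1`) gives 39900 nM, the higher of the two numbers and beyond the scatter from compound 1. Compound 3 (`CC(O)(CS(=O)(=O)c1cccc(OC(F)(F)F)c1)C(=O)Nc1ccc(S(F)(F)(F)(F)F)cc1`) differs from compound 2 in one group on an aromatic carbon: a group of 5 heavy atoms (1 carbon, 1 oxygen, 3 fluorine; no ring) in place of a group of 6 heavy atoms (5 fluorine, 1 sulfur; no ring), on an aromatic carbon. Within the data shown here, no step between measured compounds is available to size this change. In this assay the estimated step is a 1.6-fold lower number from compound 2 to compound 3 (0.20 log units; within the scatter), an expected small shift toward a lower number that stays within the scatter. For compound 3 the expected value is 25000 nM, with an estimated range of 8000 nM to 60000 nM.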

Compound 3, half-maximal inhibitory concentration: 22400 nM
For compound 3 the middle estimate is 1.1-fold (0.05 log units) above the measured one, within the range that was stated.
By their numbers in this assay, from the lowest: compound 1; then compounds 3 and 2 (each within the scatter of the next).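

In this assay, among these compounds, trifluoromethoxy in place of the group of 5 fluorine and 1 sulfur, on an aromatic carbon meta to a large group, gives the first readable step at this position (a 1.8-fold lower number from compound 2 to compound 3 (0.25 log units; within the scatter)). This exchange therefore does not separate the two groups on the shared core in this assay. No measured evidence accounts for this result.

Going by these compounds, whether an amine or a carboxylic acid at this position would give a step beyond the scatter remains open. So does the outcome of the same exchange on the core of compound 1.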